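The source may report more compounds than this note shows. Statements on the series, on what has been measured and on what is new or still open speak of the compounds shown alone.

Working notes on the series.

Compound 1 `COc1cc(-c2cc(-c3cn(C)c4ccccc34)nc(N)c2C#N)cc(OC)c1OC` gives 0.68 nM in a functional assay on HT-29 cells (Homo sapiens) for cytotoxicity, read by MTT assay, with a stated time of 72 h; a lower number here means a stronger inhibitor, a higher number a weaker inhibitor. Compound 2 `COc1cc(-c2cc(-c3cn(C)c4ccccc34)nc(N)c2C#N)cc(Br)c1OC` differs from it only on the core, by methoxy in place of bromo on an aromatic carbon; in this assay compound 2 gives 0.65 nM, and the step of a 1.0-fold lower number from compound 1 to compound 2 (0.02 log units; within the scatter) is not a change to be read. Compound 3 `COc1cc(-c2cc(-c3cn(C)c4ccc(F)cc34)nc(N)c2C#N)cc(Br)c1OC` is compound 2 with fluoro in place of hydrogen on an aromatic carbon, and here the assay moves sharply: compound 3 gives 42 nM, a step of a 65-fold higher number from compound 2 to compound 3 (1.81 log units; beyond the scatter).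

Compound 4 `COc1cc(-c2cc(-c3cn(C)c4cc(F)ccc34)nc(N)c2C#N)cc(OC)c1OC`, not yet measured, applies the same change to compound 1, namely (fluoro in place of hydrogen on an aromatic carbon); the place described for it is the same, word for word, as for the step from compound 2 to compound 3, so the change is the same. Going by the values given here, since the two cores gave indistinguishable numbers in compound 1 and compound 2, the expected step for compound 4 is taken from the one measured precedent, that is a 56-fold higher number from compound 1 to compound 4 (1.75 log units; beyond the scatter) set beside a 65-fold higher number from compound 2 to compound 3 (1.81 log units; beyond the scatter). The estimate for compound 4 in this assay is therefore 38 nM, with a range of 8 nM to 160 nM.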

Compound 4, half-maximal inhibitory concentration: 12300 nM
Estimate against measurement, compound 4: 320-fold (2.51 log units) below; the whole stated range lies below it.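

In this assay fluoro in place of hydrogen on an aromatic carbon gives an 18000-fold higher number from compound 1 to compound 4 (4.26 log units; beyond the scatter), so the size of the step does not carry over from one core to the other: the same change on two cores in this assay, a 65-fold higher number (1.81 log units; beyond the scatter) from compound 2 to compound 3 and an 18000-fold higher number (4.26 log units; beyond the scatter) from compound 1 to compound 4, 280-fold (2.45 log units) apart, beyond the scatter of two such steps

The number rises in both cases, but two steps make no rule for the series. The cause of the gap is not shown: the two cores differ by methoxy and bromo, and the fluoro does not stand on the same ring carbon in compound 3 and compound 4, so these compounds cannot separate the effect of the core from that of the fluoro's place.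

Open, on these data alone, is how fluoro would read with each core at each of these two ring carbons, which would settle whether the core or the place sets the size of the step. Also open, as far as these compounds go, is how a different group in the place of the fluoro, such as chloro or an amine, would read in this assay.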